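A Methyl for Fluoro on the Sulfonamide Aryl Ring

A few compounds are considered here, and "the series" means these few. Any claim that something is new, unique, unknown or untested is made for them only; others in the source may bear on it.

Of the compounds shown here, two have been measured so far. Compound 1 `CCN(c1ccccc1Cl)S(=O)(=O)c1cc(Cl)ccc1Cl` and compound 2 `CCN(c1ccc(F)cc1)S(=O)(=O)c1cc(Cl)ccc1Cl` share one core and differ only by 4-fluorophenyl in place of 2-chlorophenyl on the sulfonamide nitrogen. In an ADME assay on A549 cells (Homo sapiens) for cytotoxicity, read by MTT assay (a higher number here means that more compound is tolerated, a lower number that less compound is tolerated), compound 1 gives only a limit, > 5000 nM. In this assay compound 2 likewise gives only a limit, > 5000 nM. The step that the two limits leave unreadable from compound 1 to compound 2 is therefore of unreadable size, since both values sit at the limit of > 5000 nM in this assay, at which 2 of the 2 values shown sit. Compound 2 thus stands at that limit, with no measured number to set it against.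

Compound 3 `CCN(c1ccc(C)cc1)S(=O)(=O)c1cc(Cl)ccc1Cl` is not yet measured. It differs from compound 2 by methyl in place of fluoro on an aromatic carbon, a methyl in place of fluoro on an aromatic carbon. Within the data shown here, no measured step bears directly on this exchange, and the one known step is itself unreadable. Because compound 2 sits at > 5000 nM, compound 3 is expected to stay near the same limit, with a step that the limit leaves unreadable from compound 2 to compound 3 of no size beyond the scatter. The estimate for compound 3 in this assay is 9000 nM, in the range 4000 nM to 30000 nM.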

Compound 3, half-maximal cytotoxic concentration: > 25000 nM
Compound 3: a limit, no number; the forecaster's own chance of this, stated with the estimate: 75%; at least 2.7-fold (0.44 log units) between middle value and limit.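

In this assay compound 3 gives only a limit (> 25000 nM). Among these compounds, compound 1, compound 2 and compound 3 all give only limits, and no step among them can be read. The compounds shown leave open what concentration of each is tolerated, and whether methyl and fluoro differ at all in this cytotoxicity read-out.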